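Amide change from compound 2 to compound 3

The compounds below may be only part of what the source reports. "The series", "measured", "known", "first", "only" and "open" are said of these compounds alone.

In an ADME assay on L02 cells (Homo sapiens) for antiproliferative activity, read by MTT assay, with a stated time of 48 h (a higher number here means a weaker inhibitor, a lower number a stronger inhibitor), compound 1 (`CCn1c(C(=O)NCCN(C)C)ccc1C(CC)(CC)c1ccc(OCCC(O)(CC)CC)c(C)c1`) gives 990 nM while compound 2 (`CCn1c(C(=O)NC(C)C(=O)O)ccc1C(CC)(CC)c1ccc(OCCC(O)(CC)CC)c(C)c1`) gives 4040 nM as the higher of the two numbers. Compound 3 (`CCn1c(C(=O)N(C)CCO)ccc1C(CC)(CC)c1ccc(OCCC(O)(CC)CC)c(C)c1`) differs from compound 2 as follows: (2-hydroxyethyl)(methyl)amino in place of (1-carboxyethyl)amino on a carbonyl carbon. For the measured compounds named here, the only measured step bearing on this change is a 4.1-fold higher number from compound 1 to compound 2 (0.61 log units; beyond the scatter) and it also concerns the 1-carboxyethyl group. Compound 3 lacks that group, as compound 1 does, so a modest fall in this assay is expected, with a 1.7-fold lower number from compound 2 to compound 3 (0.23 log units; within the scatter) as the estimated step. Compound 3 is estimated at 2400 nM (expected range 850 nM to 6500 nM).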

Compound 3, half-maximal inhibitory concentration: 2050 nM
The estimate for compound 3 lay 1.2-fold (0.07 log units) above the measured number; the measured number falls inside the stated range.
By their numbers in this assay, from the lowest: compound 1; then compounds 3 and 2 (each within the scatter of the next).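

In this assay, (2-hydroxyethyl)(methyl)amino in place of (1-carboxyethyl)amino on the carbonyl carbon gives a 2.0-fold lower number from compound 2 to compound 3 (0.29 log units; within the scatter) and so does not separate these two amides. Against the amine-bearing amide, the same group gives a 2.1-fold higher number from compound 1 to compound 3 (0.32 log units; beyond the scatter), leaving compound 1 alone as the strongest of the three. No measurement bears on the cause of these steps.

The compounds shown leave open whether the 2-hydroxyethyl group or the methyl on the amide nitrogen sets the value of compound 3. They also leave open whether a primary amine or a longer chain ending in dimethylamino would match compound 1.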